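A Fluorine Moves Around the Ring

The source may report more compounds than this note shows. Statements on the series, on what has been measured and on what is new or still open speak of the compounds shown alone.

Three compounds have been measured in an assay on HEK293 cells for activation of Kir3.1/Kir3.2 (Homo sapiens), read by thallium flux; a lower number here means a smaller maximal response, a higher number a larger maximal response:

Compound 1 `Cc1cc(NC(=O)Cn2nnc(-c3cccc(Cl)c3)n2)n(C2CCCCC2)n1`: 89%
Compound 2 `Cc1cc(NC(=O)Cn2nnc(-c3cc(Cl)cc(Cl)c3)n2)n(C2CCCCC2)n1`: 82%
Compound 3 `Cc1cc(NC(=O)Cn2nnc(-c3ccc(F)cc3)n2)n(C2CCCCC2)n1`: 92%

The three numbers lie close together. Within the data shown here, from compound 1 to compound 3 the response moved by a number 3 percentage points higher from compound 1 to compound 3 (within the scatter), and from compound 2 to compound 3 by a number 10 percentage points higher from compound 2 to compound 3 (within the scatter); neither step is beyond the usual scatter, so no compound can be called stronger than another on these numbers.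

Compound 4 `Cc1cc(NC(=O)Cn2nnc(-c3cccc(F)c3)n2)n(C2CCCCC2)n1` is the next candidate. It differs from compound 3 in one place: 3-fluorophenyl in place of 4-fluorophenyl on an aromatic carbon. The steps already seen bear on this change only loosely. Adding a chloro group (a number 7 percentage points lower from compound 1 to compound 2 (within the scatter)) and swapping 3-chlorophenyl for 4-fluorophenyl (a number 3 percentage points higher from compound 1 to compound 3 (within the scatter)) both stayed within the scatter, which suggests this part of the molecule has so far tolerated such changes without a clear shift in maximal response.

Compound 4 is therefore expected to show a step of a number 3 percentage points lower from compound 3 to compound 4 (within the scatter), with the estimate for compound 4 being 89%, in a range from 78% to 100%.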

Compound 4, largest response reached (Emax), in percent of the reference or control that the assay uses: 96%
Estimate against measurement, compound 4: 7 percentage points below, and the stated range covers the measured number.
By their numbers in this assay, from the lowest: compounds 2, 1, 3 and 4 (each within the scatter of the next, the first and the last beyond it).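

Swapping 4-fluorophenyl for 3-fluorophenyl, which leaves the atoms unchanged, gives a number 4 percentage points higher from compound 3 to compound 4 (within the scatter) in this assay, and fluoro in place of chloro gives a number 7 percentage points higher from compound 1 to compound 4 (within the scatter), so neither moving the fluorine nor exchanging this halogen produces a clear shift. The first step to clear the scatter is 3-fluorophenyl in place of 3,5-dichlorophenyl, with a number 14 percentage points higher from compound 2 to compound 4 (beyond the scatter), a modest difference that is the only firm separation among these compounds. Nothing shown here explains why this pair separates while the others do not.

The compounds shown carry only chloro and fluoro on this phenyl ring, so they leave open how an amine, a carboxylic acid or a methoxy group there would affect the maximal response. They also leave open whether replacing the phenyl ring with a saturated ring such as cyclohexyl would be tolerated.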